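A few compounds are considered here, and "the series" means these few. Any claim that something is new, unique, unknown or untested is made for them only; others in the source may bear on it.

Values in a functional assay on KB cells (Homo sapiens) for cytotoxicity; on this read-out higher numbers stand for weaker inhibition and lower numbers for stronger inhibition:
- compound 1 `COc1ccc(S(=O)(=O)N2CCc3cccc(NC(=O)c4cccs4)c32)cc1`: 47 nM
- compound 2 `COc1ccc(S(=O)(=O)N2CCc3cccc(NS(=O)(=O)c4ccccc4)c32)cc1`: 650 nM
- compound 3 `COc1ccc(S(=O)(=O)N2CCc3cccc(N)c32)cc1`: 2800 nM

Compound 3 carries the highest number of the three. Compound 4 `COc1ccc(S(=O)(=O)N2CCc3cccc(NC(=O)c4ccc(C#N)cc4)c32)cc1` has not yet been measured. It differs from compound 3 by (4-cyanophenyl)carbonyl in place of hydrogen on a nitrogen on an aromatic ring, with (4-cyanophenyl)carbonyl in place of hydrogen on a nitrogen on an aromatic ring. Going by the values given here, the closest precedent, read in reverse, is the large 60-fold higher number from compound 1 to compound 3 (1.78 log units; beyond the scatter). The modest 4.3-fold higher number from compound 2 to compound 3 (0.63 log units; beyond the scatter) concerns a sulfonyl group, and the large 14-fold higher number from compound 1 to compound 2 (1.14 log units; beyond the scatter) favours the carbonyl link. Among the compounds with values here, no measured compound carries the entering group, so a large fall in this assay is expected, probably somewhat short of the precedent. The expected step is a 23-fold lower number from compound 3 to compound 4 (1.37 log units; beyond the scatter). The estimate for compound 4 is 120 nM, with an expected range of 25 nM to 600 nM.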

Compound 4, half-maximal inhibitory concentration: 105 nM
For compound 4 the middle estimate is 1.1-fold (0.06 log units) above the measured one; the measured number falls inside the stated range.
By their numbers in this assay, from the lowest: compound 1; then compound 4; then compound 2; then compound 3.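

In this assay, a second aryl carbonyl group on the nitrogen repeats the gain over the free amine, with a 27-fold lower number from compound 3 to compound 4 (1.43 log units; beyond the scatter), so this gain is not confined to thiophen-2-yl. The carbonyl-linked 4-cyanophenyl group also outperforms phenylsulfonyl, with a 6.2-fold lower number from compound 2 to compound 4 (0.79 log units; beyond the scatter). The aryl group still affects the result, with a 2.2-fold higher number from compound 1 to compound 4 (0.35 log units; beyond the scatter) when 4-cyanophenyl replaces thiophen-2-yl.

No evidence on the origin of these steps is available. As far as these compounds go, it remains open whether an amine or a carboxylic acid in place of the nitrile would keep this level.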